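Aryl exchange on the shared core: compound 3 to compound 4

The compounds below may be only part of what the source reports. "The series", "measured", "known", "first", "only" and "open" are said of these compounds alone.

Measured so far in a functional assay on DU-145 cells (Homo sapiens) for cytotoxicity; on this read-out higher numbers stand for weaker inhibition of growth and lower numbers for stronger inhibition of growth:
compound 1 `COc1ccc(C2=C(c3ccc(SC)cc3)CC3CCCN3C2=O)cc1OC(=O)CNC(=O)OC(C)(C)C` gives 10000 nM
compound 2 `CSc1ccc(C2=C(c3ccc(F)c(F)c3)C(=O)N3CCCC3C2)cc1` gives 500 nM
compound 3 `CSc1ccc(C2=C(c3ccc(C)c(C)c3)C(=O)N3CCCC3C2)cc1` gives 500 nM

In this assay compound 3 stands level with compound 2, and the number for compound 1 is higher than both, by a gap beyond the scatter. The next structure is compound 4 `COc1ccc(C2=C(c3ccc(SC)cc3)CC3CCCN3C2=O)cc1`, with 4-methoxyphenyl in place of 3,4-dimethylphenyl on a double-bonded ring carbon, next to the ring atom that bears a 4-(methylsulfanyl)phenyl group (4-methoxyphenyl in place of 3,4-dimethylphenyl on a double-bonded ring carbon). Within the data shown here, the only measured step at this place is the exchange of 3,4-difluorophenyl for 3,4-dimethylphenyl (no change at the digits printed from compound 2 to compound 3 (within the scatter)), which shows nothing beyond the scatter. That single step covers two groups, and 4-methoxyphenyl is not one of them, so the evidence is thin and the range is kept wide in both directions. No step beyond the scatter is therefore expected (a 1.3-fold lower number from compound 3 to compound 4 (0.10 log units; within the scatter)). Compound 4 is expected at 400 nM (estimated range 80 nM to 2000 nM).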

Compound 4, concentration for 50% growth inhibition: 900 nM
For compound 4 the middle estimate is 2.3-fold (0.35 log units) below the measured one, and the stated range covers the measured number.
By their numbers in this assay, from the lowest: compounds 2, 3 and 4 (each within the scatter of the next); then compound 1.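

In this assay the 4-methoxyphenyl group joins 3,4-difluorophenyl and 3,4-dimethylphenyl on the double-bonded ring carbon, and both a 1.8-fold higher number from compound 3 to compound 4 (0.26 log units; within the scatter) and a 1.8-fold higher number from compound 2 to compound 4 (0.26 log units; within the scatter) stay within the scatter, so these three groups are not separated at this position. The large change lies at another place, on an aromatic carbon: an 11-fold lower number from compound 1 to compound 4 (1.05 log units; beyond the scatter) with a hydrogen atom in place of a group of 12 heavy atoms. No measurement at hand accounts for either the flat steps or the large one.

Still open, going by these compounds, is whether an amine or a carboxylic acid on the double-bonded ring carbon would also stay within the scatter of these three groups. On these data alone, it is equally open whether a hydroxyl group on that aromatic carbon would give a number nearer to compound 1 or to compound 4.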